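From phenyl to 4-chlorophenyl at the edge of the assay

The source may report more compounds than this note shows. Statements on the series, on what has been measured and on what is new or still open speak of the compounds shown alone.

In a functional assay on U-251 cells (Homo sapiens) for inhibition, read by sulforhodamine B assay, with a stated time of 48 h (on this read-out lower numbers stand for stronger inhibition of growth and higher numbers for weaker inhibition of growth), compound 2 `CC(C)(C)NCc1c(C(=O)O)nn(-c2ccccc2)c1-c1ccc(Cl)cc1` gives > 652000 nM, which is a limit of the assay and not a number. Compound 2 therefore has no exact place among the values shown. Compound 3 `Cc1ccc(-c2c(CNC(C)(C)C)c(C(=O)O)nn2-c2ccccc2)cc1` gives > 688000 nM, and this too is a limit. Compound 1 `CCOC(=O)c1nn(-c2ccc(Cl)cc2)c(-c2ccc(Cl)cc2)c1CNC(C)(C)C` has two entries in this assay, given as 6400 nM; > 519000 nM (2 entries). Only the first of these two entries is a number, and the second is a limit of the assay.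

Compound 4 `CC(C)(C)NCc1c(C(=O)O)nn(-c2ccc(Cl)cc2)c1-c1ccc(Cl)cc1` differs from compound 2 by a single change, chloro in place of hydrogen on an aromatic carbon, so that phenyl becomes 4-chlorophenyl. The only measured step among these compounds is a step that the two limits leave unreadable from compound 2 to compound 3, a methyl in place of chloro on an aromatic carbon. It is a different change and has no readable size, so it sets no size for this one. Compound 2 stands at > 652000 nM, again a limit, and on that ground compound 4 is expected to give a limit as well. The expected change is an at least 1.0-fold lower number from compound 2 to compound 4 (0.03 log units; that floor lies within the scatter), estimated to show no direction and to stay within the scatter. For compound 4 the estimated value is 600000 nM, with an expected range from 60000 nM to 700000 nM.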

Compound 4, concentration for 50% growth inhibition: 518000 nM
The estimate for compound 4 lay 1.2-fold (0.06 log units) above the measured number; measured number inside the range.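

In this assay compound 2 stands at > 652000 nM as a limit of the assay and not a number. Phenyl to 4-chlorophenyl on the aromatic carbon gives an at least 1.2-fold lower number from compound 2 to compound 4 (0.09 log units; that floor lies within the scatter) and so shows no change beyond the scatter, although the limit of compound 2 leaves the true size of the step unknown. What compound 4 adds is a number: it is the only carboxylic acid shown that has one, whereas the step between the other two carboxylic acids cannot be read.

The compounds shown leave open what a fluoro or a methoxy group would give in place of this chloro, and whether a real difference lies hidden behind the limit of compound 2. They also leave open how the ethyl ester of compound 1, which carries the same two 4-chlorophenyl groups as compound 4, stands against the carboxylic acid, since its entries do not give a single value: the several entries of compound 1 in this assay, 6400 nM; > 519000 nM (2 entries)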